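A vinyl on the chain of compound 3

The compounds below may be only part of what the source reports. "The series", "measured", "known", "first", "only" and "open" are said of these compounds alone.

In a functional assay on A549 cells (Homo sapiens) for inhibition, read by colorimetric assay and MTT assay, with a stated time of 72 h (on this read-out lower numbers stand for stronger inhibition and higher numbers for weaker inhibition), compound 1 `Cn1c2cnc1OCCCCCCCCOc1cc3ccccc3cc1-2` gives 26000 nM
Compound 2 `Cn1c2cnc1OCCCCCCCCCCOc1ccccc1-2` gives 48000 nM
Compound 3 `CCCCOc1ncc(-c2ccccc2OC)n1C` gives 87000 nM

Compound 3 (87000 nM) stands within the usual scatter of compound 2, while its number lies beyond the scatter above that of compound 1. Compound 4 `C=CCCCCOc1ncc(-c2ccccc2OC)n1C` has not yet been measured. It differs from compound 3 by vinyl in place of hydrogen on a saturated chain carbon, four bonds along the chain from an oxygen on an aromatic ring.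

Among the measured compounds shown here, no measured pair tests this change, so any forecast is loose. In this assay a small step toward a lower number is expected, probably not clearly beyond the scatter. The estimated step runs a 1.5-fold lower number from compound 3 to compound 4 (0.16 log units; within the scatter) and is expected to stay modest. The low end of the range is set with compound 1 in mind, which reads 26000 nM in the same read-out. Compound 4 is estimated at 60000 nM with an expected range from 25000 nM to 120000 nM in this measurement.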

Compound 4, half-maximal inhibitory concentration: 5000 nM
The estimate for compound 4 lay 12-fold (1.08 log units) above the measured number, and the stated range ends above it.
By their numbers in this assay, from the lowest: compound 4; then compounds 1, 2 and 3 (each within the scatter of the next, the first and the last beyond it).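

In this assay, vinyl in place of hydrogen on a saturated chain carbon, four bonds along the chain from an oxygen on an aromatic ring, gives a 17-fold lower number from compound 3 to compound 4 (1.24 log units; beyond the scatter), a large step beyond the scatter. Among the compounds shown here, this shows that the position responds strongly to a group of only two carbon atoms with one double bond outside aromatic rings, which the earlier compounds could not show, as no two of them differed in one place. Nothing at hand accounts for the size of this step.

The compounds shown leave open whether the double bond or the added chain length carries the step, a question that a saturated hexyl chain would settle. Also open, on these data alone, is how an amine or a carboxylic acid in place of the vinyl would read.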